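Cytotoxicity in THP-1 cells: a fluorophenyl replaces pyrimidine

The source may report more compounds than this note shows. Statements on the series, on what has been measured and on what is new or still open speak of the compounds shown alone.

The three measured compounds share one core and differ only in the small aromatic ring attached to it. Compound 1 is `O=c1nc(-c2ccccc2)c2ccc(-c3ccncc3)cc2[nH]1`, compound 2 is `O=c1nc(-c2ccccc2)c2ccc(-c3cccnc3)cc2[nH]1` and compound 3 is `O=c1nc(-c2ccccc2)c2ccc(-c3cncnc3)cc2[nH]1`. In an ADME assay on THP-1 cells (Homo sapiens) for cytotoxicity, read by MTT assay, with a stated time of 72 h (on this read-out higher numbers stand for an effect only at larger amounts of compound and lower numbers for an effect already at smaller amounts), compound 1 reaches only the limit of the assay, > 50000 nM. In this assay compound 2 likewise gives a limit, > 50000 nM. Compound 3 too stops at a limit, > 50000 nM, so no number is known for it, only a range.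

Because all three values sit at the limit of > 50000 nM in this assay, at which 3 of the 3 values shown sit, none of the steps between them can be sized: a step that the two limits leave unreadable from compound 1 to compound 2, a step that the two limits leave unreadable from compound 1 to compound 3 and a step that the two limits leave unreadable from compound 2 to compound 3 all stay unreadable.

The next compound, compound 4, is `O=c1nc(-c2ccccc2)c2ccc(-c3ccc(F)cc3)cc2[nH]1`. It differs from compound 3 in one place: 4-fluorophenyl in place of pyrimidin-5-yl on an aromatic carbon. Within the data shown here, no measured step directly mirrors this change, and the measured steps only show that swapping one small nitrogen-bearing ring for another left every compound at the limit. The expectation for compound 4 is therefore that it, too, shows no cytotoxicity within the tested range, an expected step of a number no higher from compound 3 to compound 4 (the limit leaves the size open). The estimate for compound 4 in this assay is 50000 nM, with a range from 20000 nM to 120000 nM.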

Compound 4, half-maximal effective concentration: > 50000 nM
Compound 4 ended at the assay's limit; the forecaster's own chance of this, stated with the estimate: 75%; the middle value lies on the limit itself.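

Compound 4 also stops at a limit in this assay, so the steps linking it to compound 1, compound 2 and compound 3 cannot be read, because all four compounds give only the same limit: the limit of > 50000 nM in this assay, at which 4 of the 4 values shown sit. The compounds shown leave open whether any group at this place on the shared core brings cytotoxicity into the measurable range.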